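Three Compounds at the Limit and an Untested Fourth

The source may report more compounds than this note shows. Statements on the series, on what has been measured and on what is new or still open speak of the compounds shown alone.

Compound 1 `COc1ccc(-n2cc(-c3ccc(OC)c(O)c3)nn2)cc1`, compound 2 `COc1ccc(-c2cn(-c3ccc(Oc4ccccc4)cc3)nn2)cc1O` and compound 3 `Oc1cc(O)cc(-c2cn(-c3ccc(Oc4ccccc4)cc3)nn2)c1` were all tested in a functional assay on MDA-MB-231 cells (Homo sapiens) for cytotoxicity, read by MTT assay; a lower number here means a stronger inhibitor, a higher number a weaker inhibitor. In this assay compound 1 gives only a limit of > 10000 nM. In this assay compound 2 likewise gives only a limit, > 10000 nM. In this assay compound 3 also reaches only a limit, > 10000 nM. The change from compound 2 to compound 1 is methyl in place of phenyl on an oxygen on an aromatic ring; its step, a step that the two limits leave unreadable from compound 2 to compound 1, cannot be sized because of the limit of > 10000 nM in this assay, at which 3 of the 3 values shown sit. The cores of compound 2 and compound 3 differ by 3,5-dihydroxyphenyl in place of 3-hydroxy-4-methoxyphenyl on an aromatic carbon, and that step, a step that the two limits leave unreadable from compound 2 to compound 3, is equally unreadable because of the limit of > 10000 nM in this assay, at which 3 of the 3 values shown sit. Compound 4 `COc1ccc(-n2cc(-c3cc(O)cc(O)c3)nn2)cc1` has not been measured. It differs from compound 3 by methyl in place of phenyl on an oxygen on an aromatic ring, the same change that turns compound 2 into compound 1, at the same place. Since that change left compound 2 and compound 1 both at the limit, compound 4 is expected to stay there as well, with the step that the limit leaves unreadable from compound 3 to compound 4 estimated as essentially none. Compound 4 is therefore estimated at 20000 nM, within 8000 nM to 80000 nM, and most likely reported as a limit again.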

Compound 4, half-maximal inhibitory concentration: > 10000 nM
Compound 4: no number, only a limit; the forecaster's own chance of this, stated with the estimate: 90%; the middle value is on the limit's open side.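

The change of phenoxy to methoxy from compound 3 to compound 4 has no readable size in this assay, because both compounds give only a limit: the limit of > 10000 nM in this assay, at which 4 of the 4 values shown sit.

The four compounds shown leave open how strongly each one really acts on these cells, and whether either change of group alters that at all.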